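A few compounds are considered here, and "the series" means these few. Any claim that something is new, unique, unknown or untested is made for them only; others in the source may bear on it.

Measured so far:
compound 1, `CCOC(=O)C12C(=O)OCC=C1COC2c1ccc(Cl)cc1`, > 1000000 nM
compound 2, `CCOC(=O)C12C(=O)OCC=C1COC2c1ccc(Br)cc1`, > 1000000 nM

Compound 1 has the structure `CCOC(=O)C12C(=O)OCC=C1COC2c1ccc(Cl)cc1`. In a functional assay on QGY cells (Homo sapiens) for cytotoxicity, read by MTT assay (on this read-out lower numbers stand for stronger inhibition and higher numbers for weaker inhibition), compound 1 gives > 1000000 nM, which is a limit of the assay and not a number. Compound 2, `CCOC(=O)C12C(=O)OCC=C1COC2c1ccc(Br)cc1`, carries bromo in place of chloro on an aromatic carbon. In this assay compound 2 gives > 1000000 nM, again a limit of the assay. The step that the two limits leave unreadable from compound 1 to compound 2 cannot be read because both values sit at the limit of > 1000000 nM in this assay, at which 2 of the 2 values shown sit. Compound 3, `CCOC(=O)C12C(=O)OCC=C1COC2c1ccc(OC)cc1`, carries the change (methoxy in place of bromo on an aromatic carbon), methoxy in place of bromo on an aromatic carbon. No readable measured step bears on this change, so there is no ground to expect a step beyond the scatter in either direction. Compound 3 is therefore expected to give about 1000000 nM in this assay, within 200000 nM to 5000000 nM, most likely again only as a limit. This estimate means an expected step of a number no higher from compound 2 to compound 3 (the limit leaves the size open) that is essentially flat.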

Compound 3, half-maximal inhibitory concentration: > 1000000 nM
Compound 3: only a limit was reported; the forecaster's own chance of this, stated with the estimate: 85%; the middle value sits exactly at the limit.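

No step among compound 1, compound 2 and compound 3 can be read, because their values are limits of the assay and not numbers: the limit of > 1000000 nM in this assay, at which 3 of the 3 values shown sit.

The compounds shown leave open whether chloro, bromo and methoxy differ at all in this assay.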